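The compounds below may be only part of what the source reports. "The series", "measured", "known", "first", "only" and "open" are said of these compounds alone.

Measured so far in a functional assay on SGC-7901 cells (Homo sapiens) for antiproliferative activity, read by sulforhodamine B assay, with a stated time of 72 h; on this read-out lower numbers stand for stronger inhibition and higher numbers for weaker inhibition:
Compound 1, `S=C(N/N=C/c1ccc2ccccc2n1)Nc1ccc(Br)cc1`, gives 69400 nM.
Compound 2, `Cc1ccccc1NC(=S)N/N=C/c1ccc2ccccc2n1`, gives only a limit of the assay, > 100000 nM.
Compound 3, `S=C(N/N=C/c1ccc2ccccc2n1)Nc1cccc(Br)c1`, gives 78600 nM.

Within the data shown here, compound 2 stands at the limit of the assay with no number behind it, and it is the one value of the three that sits there (the limit of > 100000 nM in this assay, at which 1 of the 3 values shown sits). Its two steps to measured neighbours are an at least 1.4-fold higher number from compound 1 to compound 2 (0.15 log units; that floor lies within the scatter) and an at least 1.2-fold lower number from compound 2 to compound 3 (0.10 log units; that floor lies within the scatter); both are read against that limit and both lie within the scatter, so none of the three compounds is set apart from the others. Compound 1 and compound 3 are separated by a 1.1-fold higher number from compound 1 to compound 3 (0.05 log units; within the scatter), again within the scatter.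

Compound 4, `FC(F)(F)c1ccccc1NC(=S)N/N=C/c1ccc2ccccc2n1`, differs from compound 2 in one place: trifluoromethyl in place of methyl on an aromatic carbon. Among the measured compounds shown here, no measured step exchanges methyl for trifluoromethyl; every step on hand swaps the whole group on the amide-type nitrogen, and all three stayed within the scatter. The step expected in this assay is therefore a number no higher from compound 2 to compound 4 (the limit leaves the size open), nothing beyond the scatter, with a real chance that only a limit is returned again. Compound 4 is estimated at 100000 nM in this assay, within 50000 nM to 200000 nM.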

Compound 4, half-maximal inhibitory concentration: 20700 nM
The estimate for compound 4 lay 4.8-fold (0.68 log units) above the measured number, outside the stated range (below it).
By their numbers in this assay, from the lowest: compound 4; then compounds 1 and 3 (each within the scatter of the next). At a limit, above all of these: compound 2.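

In this assay, among these compounds, trifluoromethyl in place of methyl on an aromatic carbon, ortho to a large group, gives an at least 4.8-fold lower number from compound 2 to compound 4 (0.68 log units; beyond the scatter), the first step in this set that is printed as beyond the scatter. The earlier steps shown here each swapped the whole group on the amide-type nitrogen and none could be told apart from repeat scatter, whereas this one shows that a single exchange at this position on the six-membered aromatic ring can set a compound apart from its neighbour. Going by these compounds, compound 2 is only a limit of the assay, so the step is a floor and its true size stays open: the limit of > 100000 nM in this assay, at which 1 of the 4 values shown sits.

On these data alone, whether a chlorine, a methoxy or a nitrile at this position would behave like trifluoromethyl or like methyl stays open, as does whether trifluoromethyl elsewhere on the same ring would give a step of this size. The change rests on one pair of compounds, and what property of the group carries the step cannot be read from it, so no wider pattern across the series can be claimed yet.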